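Swapping benzyl for a dimethylaminoethyl chain on the core

The source may hold more compounds than are shown below. What is called first, only, known or untested is meant among the compounds shown, and "the series" means these compounds.

Compound 1 `O=C(Nc1ccc(C(=O)N2CCCN(Cc3ccccc3)c3sccc32)cc1)c1ccccc1-c1ccccc1` gives 80 nM in an assay on CHO cells for inhibition of Vasopressin V2 receptor (Homo sapiens), read by radioligand binding (on this read-out higher numbers stand for weaker inhibition and lower numbers for stronger inhibition), the highest of the three numbers reported so far. Compound 3 `COc1cc(C(=O)N2CCCC(N(C)C)c3sccc32)ccc1NC(=O)c1ccccc1-c1ccccc1` gives 20 nM in this assay, and compound 2 `CN1CCN(CCCCOc2cc(C(=O)N3CCCCc4sccc43)ccc2NC(=O)c2ccccc2-c2ccccc2)CC1` gives 1 nM; neither pair is a single-point comparison with compound 1, so only the values themselves can be set side by side. Compound 4 `CN(C)CCN1CCCN(C(=O)c2ccc(NC(=O)c3ccccc3-c3ccccc3)cc2)c2ccsc21` has not yet been measured; it differs from compound 1 by (dimethylamino)methyl in place of phenyl on a saturated chain carbon bound to a nitrogen on an aromatic ring in a ring. Among the compounds with values here, no measured pair shows this exact change, so the direction is an expectation only. The author expects a moderate step toward a lower number, a 3.2-fold lower number from compound 1 to compound 4 (0.51 log units; beyond the scatter), which is beyond the scatter. For compound 4 the estimate in this assay is 25 nM, between 6 nM and 100 nM.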

Compound 4, half-maximal inhibitory concentration: 80 nM
Compound 4: middle estimate off by 3.2-fold (0.51 log units), on the low side; the range from low to high includes it.
By their numbers in this assay, from the lowest: compound 2; then compound 3; then compounds 1 and 4 (each within the scatter of the next).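

In this assay, replacing benzyl with 2-(dimethylamino)ethyl gives no change at the digits printed from compound 1 to compound 4 (within the scatter). Within the data shown here, this is the only comparison here that isolates a single place, and it shows that a six-membered aromatic ring of carbon only can give way, on this saturated chain carbon, to a chain with no ring and one hydrogen-bond acceptor without a readable shift. Nothing at hand accounts for this outcome.

On these data alone, it remains open whether a carboxylic acid or a longer chain ending in an amine would move the number at this place. The compounds shown also leave unresolved which of their several differences sets compound 2 and compound 3 apart from compound 1 and compound 4.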